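Swapping a benzyloxy arm for a plain phenyl ring

The source may hold more compounds than are shown below. What is called first, only, known or untested is meant among the compounds shown, and "the series" means these compounds.

Measured so far:
compound 1, `CCCOc1cccc(C(=O)Nc2cccc(C(=O)O)c2)c1`, gives 2150 nM in an assay on isolated protein for agonist activity at Bile acid receptor (Homo sapiens), read by TR-FRET, with a stated time of 3 h, in the absence of a further agent; a higher number here means that more compound is needed for the effect, a lower number that less compound is needed;
compound 2, `Cc1cccc(COc2cccc(C(=O)Nc3cccc(C(=O)O)c3)c2)c1`, gives 1860 nM in this assay.

Compound 2 holds the lowest of the two numbers, and compound 1 sits nearest to it; the two lie within the scatter of each other, so no order can be claimed between them. Among the compounds with values here, the single measured step, a 1.2-fold lower number from compound 1 to compound 2 (0.06 log units; within the scatter), changed only the group hanging off the oxygen and left the number essentially where it was.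

Compound 3, `O=C(O)c1cccc(NC(=O)c2cccc(-c3ccccc3)c2)c1`, goes further: phenyl in place of (3-methylbenzyl)oxy on an aromatic carbon. The oxygen link disappears and a ring sits directly on the core. The measured step speaks to the alkoxy substituent, not to its removal, so it bears only loosely here. The expectation is a step of about a 1.3-fold higher number from compound 2 to compound 3 (0.13 log units; within the scatter), small and within the scatter, in this assay. Compound 3 is thus estimated at 2500 nM, with a range of 800 nM to 8000 nM.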

Compound 3, half-maximal effective concentration: 25 nM
Beside the measured number, compound 3's estimate is 100-fold (2.00 log units) above it, and the stated range ends above it.
By their numbers in this assay, from the lowest: compound 3; then compounds 2 and 1 (each within the scatter of the next).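

At this aromatic carbon, exchanging one oxygen-linked group for another gave no readable change, yet in this assay phenyl brings a 74-fold lower number from compound 2 to compound 3 (1.87 log units; beyond the scatter) and an 86-fold lower number from compound 1 to compound 3 (1.93 log units; beyond the scatter), so the position responds strongly to some changes. The step from compound 2 also shows that merely having an aromatic ring in this region does not settle the number, since the leaving (3-methylbenzyl)oxy and the entering phenyl each hold one six-membered aromatic ring of carbon only. Nothing available explains why this change has so large an effect.

Still open, going by these compounds, is whether the drop follows from losing the oxygen link, the intervening carbon or the methyl group. A benzyl group or a cyclohexyl ring at this carbon would help separate these possibilities, and a pyridine ring would test whether a ring of carbon only is needed.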